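A few compounds are considered here, and "the series" means these few. Any claim that something is new, unique, unknown or untested is made for them only; others in the source may bear on it.

Going by the values given here, in an ADME assay on SH-SY5Y cells (Homo sapiens) for cytotoxicity, read by MTT assay, with a stated time of 72 h (a higher number here means a weaker inhibitor, a lower number a stronger inhibitor), compound 1 (`O=C(CN1CCN(C(=O)c2ccc(Cl)cc2)CC1)N1CCN(CCCc2c[nH]c3ccccc23)CC1`) gives 139000 nM and compound 2 (`O=C(CN1CCN(C(=O)c2cccc(F)c2)CC1)N1CCN(CCCc2c[nH]c3ccccc23)CC1`) gives 165000 nM as values within the scatter of each other, so compound 2 stands level with the only other measured compound. Compound 3 (`O=C(CN1CCN(C(=O)c2ccccc2F)CC1)N1CCN(CCCc2c[nH]c3ccccc23)CC1`) differs from compound 2 by 2-fluorophenyl in place of 3-fluorophenyl on a carbonyl carbon and carries 2-fluorophenyl in place of 3-fluorophenyl on a carbonyl carbon. Among the compounds with values here, the one measured step (a 1.2-fold higher number from compound 1 to compound 2 (0.07 log units; within the scatter)) is a change at that same place and gives no sign of a real shift. The estimated step is a 1.1-fold lower number from compound 2 to compound 3 (0.04 log units; within the scatter) and none beyond the scatter is expected in this assay here. Compound 3 is expected at 150000 nM with an estimated range from 90000 nM to 260000 nM in this measurement.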

Compound 3, half-maximal inhibitory concentration: 82600 nM
For compound 3 the middle estimate is 1.8-fold (0.26 log units) above the measured one, and the stated range ends above it.
By their numbers in this assay, from the lowest: compounds 3, 1 and 2 (each within the scatter of the next).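

In this assay, 2-fluorophenyl in place of 3-fluorophenyl on the carbonyl carbon gives a 2.0-fold lower number from compound 2 to compound 3 (0.30 log units; within the scatter), and 2-fluorophenyl in place of 4-chlorophenyl gives a 1.7-fold lower number from compound 1 to compound 3 (0.23 log units; within the scatter). A third aryl group at this position thus still produces no step beyond the scatter, and this now holds for a change of fluorine placement as well as for a change of halogen. No measurement bearing on the reason for these numbers is available.

As far as these compounds go, whether an amine or a carboxylic acid on this phenyl ring would give a real shift remains open. So does the effect of any change elsewhere in the shared core.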